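The compounds below may be only part of what the source reports. "The series", "measured", "known", "first", "only" and "open" are said of these compounds alone.

Measured so far:
- compound 1, `COC(=O)C1=C(C)N=C(C)/C(=C(\O)OC)C1c1ccccc1C#N`: 15.9 nM
- compound 2, `CCOc1ccccc1C1C(C(=O)OC)=C(C)N=C(C)/C1=C(\O)OC`: 110 nM
- compound 3, `COC(=O)C1=C(C)N=C(C)/C(=C(\O)OC)C1c1cc(OC)c(OC)cc1OC`: 1000000 nM

In a functional assay (muscle tissue) with Cavia porcellus as the target (on this read-out higher numbers stand for an effect only at larger amounts of compound and lower numbers for an effect already at smaller amounts), compound 1 gives the lowest of the three numbers; compound 2 lies closest, and compound 3 is furthest away. Compound 4, `COC(=O)C1=C(C)N=C(C)/C(=C(\O)OC)C1c1cccc(C#N)c1`, has not yet been measured. It differs from compound 1 in one place: 3-cyanophenyl in place of 2-cyanophenyl on a saturated ring carbon. Among the measured compounds shown here, the only step measured between neighbouring compounds, a 6.9-fold higher number from compound 1 to compound 2 (0.84 log units; beyond the scatter), swaps the group on the aromatic ring rather than moving it, so it does not bear directly on this change. The value of compound 3 shows that what sits on this aromatic ring can matter greatly, but nothing here tells how moving the nitrile alone would act. For the measured compounds named here, with no step to lean on, the expected change in this assay from compound 1 to compound 4 is none beyond the scatter, a 1.3-fold higher number from compound 1 to compound 4 (0.10 log units; within the scatter), and the estimate for compound 4 is 20 nM, with a range from 5 nM to 80 nM.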

Compound 4, half-maximal effective concentration: 34.7 nM
The estimate for compound 4 lay 1.7-fold (0.24 log units) below the measured number; the measured number falls inside the stated range.
By their numbers in this assay, from the lowest: compound 1; then compound 4; then compound 2; then compound 3.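

Moving the nitrile while keeping every atom the same gives, in this assay, a 2.2-fold higher number from compound 1 to compound 4 (0.34 log units; beyond the scatter). The earlier step showed that changing which group sits on the aromatic ring can shift the number; this one shows that the location of the same group on that ring also counts, since 2-cyanophenyl and 3-cyanophenyl are separated beyond the scatter, though only modestly. Nothing measured here explains why the two arrangements differ.

Going by these compounds, whether moving another group in the same way, such as an amine or a chlorine atom, would give a step of similar size stays open. So does the question of whether the ethoxy group of compound 2 would respond to such a move as the nitrile does.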